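The source may report more compounds than this note shows. Statements on the series, on what has been measured and on what is new or still open speak of the compounds shown alone.

Working notes on the series. Among the compounds with values here, compound 2 `Cc1ccc(S(=O)(=O)/N=C(/CCNC2=CC(=O)c3ccccc3C2=O)NCc2ccccc2)cc1` carries the lowest number of the two measured so far: in a functional assay on DU-145 cells (Homo sapiens) for cytotoxicity, read by MTT assay, with a stated time of 48 h (on this read-out higher numbers stand for weaker inhibition and lower numbers for stronger inhibition), compound 2 gives 9120 nM, while compound 1 `COc1ccc(N/C(CCNC2=CC(=O)c3ccccc3C2=O)=N\S(=O)(=O)c2ccc(C)cc2)c(OC)c1` gives 67300 nM. Within the data shown here, the one step measured, a 7.4-fold lower number from compound 1 to compound 2 (0.87 log units; beyond the scatter), ran toward a smaller group on the amine nitrogen. Compound 3 `Cc1ccc(S(=O)(=O)/N=C(\N)CCNC2=CC(=O)c3ccccc3C2=O)cc1` goes one cut further: hydrogen in place of benzyl on an amine nitrogen, benzylamino to amino. Among the measured compounds shown here, no measured step removes a group from this nitrogen outright, so the prior step is only a loose guide. A shift near or within the scatter is expected, a 1.3-fold higher number from compound 2 to compound 3 (0.12 log units; within the scatter). Compound 3 is therefore estimated at 12000 nM, between 3000 nM and 50000 nM.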

Compound 3, half-maximal inhibitory concentration: 30900 nM
Compound 3: middle estimate off by 2.6-fold (0.41 log units), on the low side, and the stated range covers the measured number.
By their numbers in this assay, from the lowest: compound 2; then compound 3; then compound 1.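

Hydrogen on this amine nitrogen now gives a reference point for its substituents. Benzyl proves better than no group at all, with a 3.4-fold higher number from compound 2 to compound 3 (0.53 log units; beyond the scatter) on its removal, while 2,4-dimethoxyphenyl proves worse, with a 2.2-fold lower number from compound 1 to compound 3 (0.34 log units; beyond the scatter) on its replacement, so the two aromatic groups fall on opposite sides of hydrogen. No measured evidence on the series explains this order.

As far as these compounds go, whether phenethyl or methyl on this nitrogen would stand nearer compound 2 or compound 3 stays open. So does the place of an unsubstituted phenyl relative to compound 1.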